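Chloro in Place of Nitro: What One Step Suggests

The source may hold more compounds than are shown below. What is called first, only, known or untested is meant among the compounds shown, and "the series" means these compounds.

Going by the values given here, in a functional assay on MCF7 cells (Homo sapiens) for cytotoxicity, read by sulforhodamine B assay (a lower number here means that less compound is tolerated, a higher number that more compound is tolerated), compound 2 `CC1=CC[C@@H]([C@@](C)(O)CCCC(C)(C)NC(=S)N/N=C\c2cccc([N+](=O)[O-])c2)CC1` gives 47300 nM as the only true number so far. The other measured compound, compound 1 `CC1=CC[C@@H]([C@@](C)(O)CCCC(C)(C)NC(=S)N/N=C\c2ccc(N(C)C)cc2)CC1`, gives > 100000 nM as a limit of the assay and not a number.

Compound 3 `CC1=CC[C@@H]([C@@](C)(O)CCCC(C)(C)NC(=S)N/N=C\c2cccc(Cl)c2)CC1` keeps the shared core of compound 2 and changes one group, with chloro in place of nitro on an aromatic carbon, meta to a large group chloro in place of nitro on an aromatic carbon as the whole difference. Among the compounds with values here, no measured step exchanges nitro for chloro. Within the data shown here, one measured step bears on this only loosely, namely an at least 2.1-fold lower number from compound 1 to compound 2 (0.32 log units; beyond the scatter) in which 3-nitrophenyl replaced 4-(dimethylamino)phenyl. From the compounds shown here alone, that step lies beyond the scatter, yet its true size stays open, and one end of it is a limit.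

Compound 2 at 47300 nM is therefore the nearest anchor, and a small move from it is expected, leaning slightly towards a lower number. The expected change is a 1.4-fold lower number from compound 2 to compound 3 (0.13 log units; within the scatter) and would stay within the scatter. In this assay the estimate for compound 3 is 35000 nM with an expected range from 12000 nM to 100000 nM as its upper end.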

Compound 3, concentration lethal to 50% of the cells: 45900 nM
Compound 3: middle estimate off by 1.3-fold (0.12 log units), on the low side; low and high end bracket the measured number.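

The exchange of nitro for chloro on an aromatic carbon, meta to a large group, now has a direct reading in this assay: it gives a 1.0-fold lower number from compound 2 to compound 3 (0.01 log units; within the scatter), so the two groups cannot be told apart at this position in this assay, even though chloro enters with 1 heavy atom and no hydrogen-bond acceptors where nitro leaves with 3 heavy atoms and 2 hydrogen-bond acceptors. Going by these compounds alone, the replacement of 4-(dimethylamino)phenyl, earlier seen only with 3-nitrophenyl, now has a second reading with 3-chlorophenyl, an at least 2.1-fold lower number from compound 1 to compound 3 (0.33 log units; beyond the scatter), so that step beyond the scatter does not depend on nitro alone. Compound 1 stands at a limit and not a number, so the true size of that step stays open: the limit of > 100000 nM in this assay, at which 1 of the 3 values shown sits.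

The compounds shown leave open whether a different group on this aromatic carbon, such as an amine or a carboxylic acid, would separate from nitro and chloro. The steps from compound 1 also change the group and its place on the ring together, so these two contributions cannot be told apart.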